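A few compounds are considered here, and "the series" means these few. Any claim that something is new, unique, unknown or untested is made for them only; others in the source may bear on it.

Three compounds in this set have clearance numbers in an ADME assay on liver for metabolic stability, with Liver microsome (Homo sapiens) as the target, read by LC-MS, using microsomes, with a stated time of 5 h; on this read-out lower numbers stand for slow clearance and higher numbers for fast clearance. Compound 1 `O[C@]1(c2ccccn2)CC[C@H](c2ccc(C(F)(F)F)cc2)C1` gives 333 mL/min/kg in this assay, the highest of the three. Compound 3 `OC(c1ccccn1)C1(c2ccc(Cl)c(Cl)c2)COC1` gives 133 mL/min/kg in this assay. Compound 2 `C[C@]1(O)C[C@](c2cc(C(F)(F)F)ccn2)([C@H](O)c2ccccn2)C1` gives 33.3 mL/min/kg in this assay, the lowest of the three numbers; the gap to compound 3 and the larger gap to compound 1 both lie beyond the scatter. Going by the values given here, no pair of these measured compounds differs in one place only, so no single-change step is at hand.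

Compound 4 `O[C@H](c1ccccn1)[C@]1(c2cc(C(F)(F)F)ccn2)C[C@H](O)C1` is the next compound to be measured in this assay. It differs from compound 2 in one place: hydrogen in place of methyl on a saturated ring carbon, on a saturated ring carbon of a four-membered non-aromatic ring of carbon only. Among the compounds with values here, no measured pair shows what this change does in this assay, so the expectation rests on compound 2 alone and on the small size of the change. A step of a 1.2-fold higher number from compound 2 to compound 4 (0.08 log units; within the scatter) is expected, which would stay within the scatter of repeated measurements. Compound 4 is therefore expected to give about 40 mL/min/kg in this assay, with a range from 15 mL/min/kg to 110 mL/min/kg.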

Compound 4, clearance: 33.3 mL/min/kg
For compound 4 the middle estimate is 1.2-fold (0.08 log units) above the measured one; the measured number falls inside the stated range.
By their numbers in this assay, from the lowest: compounds 2 and 4 (each within the scatter of the next); then compound 3; then compound 1.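

In this assay, hydrogen in place of methyl on a saturated ring carbon of the four-membered non-aromatic ring of carbon only gives a step of no change at the digits printed from compound 2 to compound 4 (within the scatter). Going by these compounds alone, this is the only single-change reading so far, and it shows that the methyl at this position can go without a measurable shift in clearance, at least on this core and with everything else held as in compound 2. Nothing measured here speaks to why the read-out stays level.

Going by these compounds, whether a larger group on this ring carbon, such as an ethyl group, a methoxymethyl chain or an amine, would also leave the read-out level remains open. The finding rests on this one pair, so whether the same change behaves alike on another core cannot be told.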